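Swapping the benzylamino end of the chain for dipropylamino

The compounds below may be only part of what the source reports. "The series", "measured", "known", "first", "only" and "open" are said of these compounds alone.

Compound 1 `CC(C)c1cn2ccccc2c1S(=O)(=O)c1ccc(OCCCNCc2ccccc2)cc1` is the stronger of the two measured compounds. In a functional assay (aorta) with Rattus norvegicus as the target (on this read-out lower numbers stand for stronger inhibition and higher numbers for weaker inhibition), compound 1 gives 22.8 nM, the lowest number of the two. Its nearest neighbour is compound 2 `CCN(CC)CCCOc1ccc(S(=O)(=O)c2c(C(C)C)cn3ccccc23)cc1`, which in this assay gives 228 nM. Among the compounds with values here, the only measured step, a 10-fold higher number from compound 1 to compound 2 (1.00 log units; beyond the scatter), replaces the benzylamino group at the end of the three-carbon chain with diethylamino, and the number rises clearly beyond the scatter.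

Compound 3 `CCCN(CCC)CCCOc1ccc(S(=O)(=O)c2c(C(C)C)cn3ccccc23)cc1` carries the change (dipropylamino in place of benzylamino on a saturated chain carbon, three bonds along the chain from an oxygen on an aromatic ring). Dipropylamino, like diethylamino, is an open-chain amine without the six-membered aromatic ring that benzylamino brings, so the step from compound 1 to compound 2 is the one comparison that bears on this new compound. On that basis a weakening of similar size is expected, with a 7.5-fold higher number from compound 1 to compound 3 (0.87 log units; beyond the scatter) as the estimated step. Compound 3 is therefore expected to give about 170 nM in this assay, with a likely range from 60 nM to 500 nM; a single measured step leaves the exact size uncertain.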

Compound 3, half-maximal inhibitory concentration: 102 nM
Estimate against measurement, compound 3: 1.7-fold (0.22 log units) above; the range from low to high includes it.
By their numbers in this assay, from the lowest: compound 1; then compound 3; then compound 2.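

In this assay the two open-chain amines do not give the same number: a 2.2-fold lower number from compound 2 to compound 3 (0.35 log units; beyond the scatter) when dipropylamino takes the place of diethylamino, and this step lies beyond the scatter. So at the end of the chain, three bonds along from the oxygen on the aromatic ring, the result depends on which groups the nitrogen carries, and not only on whether benzylamino is present. Benzylamino still gives the lowest number of the three, with a 4.5-fold higher number from compound 1 to compound 3 (0.65 log units; beyond the scatter) on going to dipropylamino, and no measurement available here explains why the numbers move in this way.

Leaving benzylamino removes both the six-membered aromatic ring and the hydrogen-bond donor in one change, so these compounds cannot show which loss goes with the higher numbers, and benzyl(methyl)amino, which keeps the ring but has no such donor, would separate the two. Also open, from the compounds shown here alone, is whether the lower number seen with the longer chains on the nitrogen would continue with dibutylamino, or how a ring amine such as piperidine would compare.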